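A few compounds are considered here, and "the series" means these few. Any claim that something is new, unique, unknown or untested is made for them only; others in the source may bear on it.

Compound 1, `CC1=NN(c2ccccc2)C(=O)C12C=CC(=O)C=C2c1cccc(C)c1`, gives 16500 nM in a functional assay on A549 cells (Homo sapiens) for antiproliferative activity, read by CCK-8 assay, with a stated time of 72 h; on this read-out lower numbers stand for stronger inhibition and higher numbers for weaker inhibition; compound 2, `CC1=NN(c2ccccc2)C(=O)C12C=CC(=O)C=C2c1ccc(C)cc1`, gives 19300 nM; compound 3, `CC1=NN(c2ccc(Br)cc2)C(=O)C12C=CC(=O)C=C2c1ccc(C)cc1`, gives 27400 nM.

Compound 4 is `CC1=NN(c2ccc(Br)cc2)C(=O)C12C=CC(=O)C=C2c1cccc(C)c1`, not yet measured. It differs from compound 3 by 3-methylphenyl in place of 4-methylphenyl on a double-bonded ring carbon. The same change was already made once, from compound 2 to compound 1, as 3-methylphenyl in place of 4-methylphenyl on a double-bonded ring carbon, and there it gave a 1.2-fold lower number from compound 2 to compound 1 (0.07 log units; within the scatter). The two cores on which the change is made differ by bromo in place of hydrogen on an aromatic carbon, a change whose step was a 1.4-fold higher number from compound 2 to compound 3 (0.15 log units; within the scatter). Since the place of the change reads the same in both pairs, this is the same change on a core that differs only by the bromo. Resting on the step seen from compound 2 to compound 1, compound 4 is expected to sit close to compound 3, with the expected step being a 1.2-fold lower number from compound 3 to compound 4 (0.08 log units; within the scatter). The estimate for compound 4 in this assay is 23000 nM, with a range from 12000 nM to 45000 nM.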

Compound 4, half-maximal inhibitory concentration: 45400 nM
Beside the measured number, compound 4's estimate is 2.0-fold (0.30 log units) below it, outside the stated range (above it).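

In this assay, 3-methylphenyl in place of 4-methylphenyl on the bromo-bearing core gives a 1.7-fold higher number from compound 3 to compound 4 (0.22 log units; within the scatter), and this step does not differ from the one seen on the core without bromo: the same change on two cores in this assay, a 1.2-fold lower number (0.07 log units; within the scatter) from compound 2 to compound 1 and a 1.7-fold higher number (0.22 log units; within the scatter) from compound 3 to compound 4, 1.9-fold (0.29 log units) apart, within the scatter of two such steps. Bromo in place of hydrogen, on the core carrying 3-methylphenyl, gives a 2.8-fold higher number from compound 1 to compound 4 (0.44 log units; beyond the scatter), which lies beyond the scatter, yet it too does not differ from the earlier bromo step: the same change on two cores in this assay, a 1.4-fold higher number (0.15 log units; within the scatter) from compound 2 to compound 3 and a 2.8-fold higher number (0.44 log units; beyond the scatter) from compound 1 to compound 4, 1.9-fold (0.29 log units) apart, within the scatter of two such steps. The methyl shift thus carries across these two cores without a measurable difference, but this rests on a single pair of steps and does not show that it would carry to other cores.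

On these data alone, whether an amine or a carboxylic acid in place of the bromo would move the number remains open.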